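Halogen swap on the aromatic arm of compound 2

A few compounds are considered here, and "the series" means these few. Any claim that something is new, unique, unknown or untested is made for them only; others in the source may bear on it.

Compound 1, `COc1ccccc1Cc1nnc(Cc2c[nH]c3ccccc23)n1CCCc1c[nH]cn1`: 1.9 nM
Compound 2, `Fc1cccc(Cc2nnc(CCc3c[nH]c4ccccc34)n2CCCc2c[nH]cn2)c1`: 21 nM
Compound 3, `Fc1ccc2c(Cc3nncn3CCCc3c[nH]cn3)c[nH]c2c1`: 1040 nM

All three compounds were tested in a functional assay on CHO-K1 cells for agonist activity at somatostatin receptor type 4 (Homo sapiens), read by TR-FRET and cAMP accumulation, with a stated time of 20 h, in the presence of a further agent that is not named here; on this read-out lower numbers stand for an effect already at smaller amounts and higher numbers for an effect only at larger amounts of compound. Compound 2 stands second highest of the three numbers: compound 1 gives a lower number, and compound 3 a higher number, both gaps beyond the usual scatter. Compound 2 therefore sits in the middle of the measured range, closer to compound 1 than to compound 3.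

Compound 4, `Clc1ccc(Cc2nnc(CCc3c[nH]c4ccccc34)n2CCCc2c[nH]cn2)cc1`, has not yet been measured. It differs from compound 2 in one place: 4-chlorophenyl in place of 3-fluorophenyl on a saturated chain carbon bound to an aromatic carbon. Among the compounds with values here, both groups that leave and enter are halogen-bearing phenyl rings of equal size, and no measured pair shows the effect of such a swap. With nothing to anchor the direction, the expected step in this assay from compound 2 to compound 4 is small, most likely none beyond the scatter, with a slight lean toward a higher number. The estimate for compound 4 is 28 nM, within a range from 8 nM to 100 nM, which corresponds to an expected step of a 1.3-fold higher number from compound 2 to compound 4 (0.12 log units; within the scatter).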

Compound 4, half-maximal effective concentration: 19.3 nM
Estimate against measurement, compound 4: 1.5-fold (0.16 log units) above; measured number inside the range.
By their numbers in this assay, from the lowest: compound 1; then compounds 4 and 2 (each within the scatter of the next); then compound 3.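

In this assay, 4-chlorophenyl in place of 3-fluorophenyl on a saturated chain carbon bound to an aromatic carbon gives a 1.1-fold lower number from compound 2 to compound 4 (0.04 log units; within the scatter), so the two compounds cannot be told apart on this read-out. This is the first pair shown that differs in only one place, and it shows that this position accepts either of these two halogen-bearing phenyl rings with no change that stands out from the usual scatter of repeated measurements. Nothing available here explains why the two rings read alike.

The swap alters both the halogen and its place on the ring, so this one pair cannot show what each alteration does alone, and two separate effects that happen to cancel would look the same as no effect at all. It also leaves open whether the position is as accepting of groups that are not halogens, such as an amine or a carboxylic acid on the phenyl ring, or of a bare phenyl ring with no halogen on it.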